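The compounds below may be only part of what the source reports. "The series", "measured", "known", "first", "only" and "open" are said of these compounds alone.

Measured so far:
- compound 1 `Cc1cn([C@@H]2O[C@H](CO[Si](C)(C)C(C)(C)C)[C@@]3(OS(=O)(=O)C=C3NCC(N)=O)[C@H]2O[Si](C)(C)C(C)(C)C)c(=O)n(C)c1=O`; in a functional assay on MT4 cells (Homo sapiens) (on this read-out higher numbers stand for lower toxicity in this test and lower numbers for higher toxicity in this test), compound 1 gives 14900 nM
- compound 2 `CCOC(=O)CNC(=O)NC1=CS(=O)(=O)O[C@@]12[C@@H](CO[Si](C)(C)C(C)(C)C)O[C@@H](n1cc(C)c(=O)n(C)c1=O)[C@@H]2O[Si](C)(C)C(C)(C)C`; in this assay compound 2 gives 3780 nM
- compound 3 `Cc1cn([C@@H]2O[C@H](CO[Si](C)(C)C(C)(C)C)[C@@]3(OS(=O)(=O)C=C3NCC(=O)OCc3ccccc3)[C@H]2O[Si](C)(C)C(C)(C)C)c(=O)n(C)c1=O`; in this assay compound 3 gives 250000 nM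

Compound 3 stands highest of the three, meaning least toxic in this assay: the step of a 17-fold higher number from compound 1 to compound 3 (1.22 log units; beyond the scatter) and the step of a 66-fold higher number from compound 2 to compound 3 (1.82 log units; beyond the scatter) are both beyond the scatter. Compound 4 `Cc1cn([C@@H]2O[C@H](CO[Si](C)(C)C(C)(C)C)[C@@]3(OS(=O)(=O)C=C3NCC(=O)C(N)=O)[C@H]2O[Si](C)(C)C(C)(C)C)c(=O)n(C)c1=O` has not yet been measured. It differs from compound 3 in a single place: carbamoyl in place of benzyloxy on a carbonyl carbon. Going by the values given here, only one measured step bears on this, and it runs the other way: from compound 1 to compound 3, benzyloxy took the place of amino on a carbonyl carbon, and the number rose by a 17-fold higher number from compound 1 to compound 3 (1.22 log units; beyond the scatter). Compound 4 removes that benzyloxy again and ends its chain in carbamoylcarbonyl, so it resembles compound 1 more than compound 3. A large drop in this assay is therefore expected, roughly undoing that earlier rise; the expected step is a 13-fold lower number from compound 3 to compound 4 (1.10 log units; beyond the scatter). Compound 4 is estimated at 20000 nM, with a range from 5000 nM to 80000 nM.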

Compound 4, half-maximal cytotoxic concentration: 9590 nM
For compound 4 the middle estimate is 2.1-fold (0.32 log units) above the measured one; the range from low to high includes it.
By their numbers in this assay, from the lowest: compound 2; then compounds 4 and 1 (each within the scatter of the next); then compound 3.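

In this assay the high number of compound 3 now looks tied to its benzyloxy group: a second replacement on the same carbonyl carbon, carbamoyl, also brings the number down (a 26-fold lower number from compound 3 to compound 4 (1.42 log units; beyond the scatter)). Carbamoyl and amino at this place cannot be told apart (a 1.6-fold lower number from compound 1 to compound 4 (0.19 log units; within the scatter)), so two different small groups land at a similar level, far from compound 3. The (carbamoylcarbonyl)methyl chain also stands modestly clear of the ((ethoxycarbonyl)methyl)carbamoyl group on the amine nitrogen (a 2.5-fold higher number from compound 2 to compound 4 (0.40 log units; beyond the scatter)), which shows that not all small chains at this nitrogen give the same number. No measurement here explains any of these differences. From the compounds shown here alone, whether methoxy on this carbonyl carbon, which keeps the ester oxygen without the aromatic ring, would stay as high as compound 3 remains open, as does the result for a carboxylic acid.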